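The source may hold more compounds than are shown below. What is called first, only, known or untested is meant among the compounds shown, and "the series" means these compounds.

Compound 1 `c1ccc(CNCCCCN(C[C@H]2Cc3ccccc3CN2)[C@H]2CCCc3cccnc32)cc1`: in a functional assay on cells for agonist activity at C-X-C chemokine receptor type 4 (Homo sapiens), read by fluorescence and calcium flux, with a stated time of 90 s (on this read-out higher numbers stand for an effect only at larger amounts of compound and lower numbers for an effect already at smaller amounts), compound 1 gives > 30000 nM, which is a limit of the assay and not a number.
Compound 2 `NCc1ccccc1CN(C[C@H]1Cc2ccccc2CN1)[C@H]1CCCc2cccnc21`: in this assay compound 2 gives > 30000 nM, again a limit.
Compound 3 `C(=C/CN(C[C@H]1Cc2ccccc2CN1)[C@H]1CCCc2cccnc21)\CNC1CCOCC1`: in this assay compound 3 gives > 30000 nM, also a limit.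

Compound 3 therefore stands at a limit, not at a measured number, and the same holds for the other two compounds: the limit of > 30000 nM in this assay, at which 3 of the 3 values shown sit. Every value is a limit. Among the compounds with values here, none of the measured steps can be sized: the step that the two limits leave unreadable from compound 1 to compound 2, the step that the two limits leave unreadable from compound 1 to compound 3 and the step that the two limits leave unreadable from compound 2 to compound 3 all remain unreadable.

Compound 4 `C(=C/CN(C[C@H]1Cc2ccccc2CN1)[C@H]1CCCc2cccnc21)\CNCc1cccnc1` differs from compound 3 in one place: (pyridin-3-yl)methyl in place of oxan-4-yl on an amine nitrogen. Within the data shown here, no measured step bears on this change with a readable size, so nothing in the data points to a shift in either direction in this assay beyond the scatter. The estimated step is a number no higher from compound 3 to compound 4 (the limit leaves the size open), meaning compound 4 is expected most likely to sit at a limit as well. Compound 4 is estimated at 30000 nM, with a range from 5000 nM to 100000 nM.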

Compound 4, half-maximal effective concentration: > 30000 nM
Compound 4: only a limit was reported; the forecaster's own chance of this, stated with the estimate: 85%; the middle value sits exactly at the limit.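

Compound 4 sits at a limit, as do compound 1, compound 2 and compound 3, so no step among these compounds can be read: the limit of > 30000 nM in this assay, at which 4 of the 4 values shown sit. The compounds shown leave open whether (pyridin-3-yl)methyl in place of oxan-4-yl shifts the effect at all in this assay.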